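The source may hold more compounds than are shown below. What is called first, only, known or untested is meant among the compounds shown, and "the series" means these compounds.

Series notes. Compound 1 `COc1ccc(Oc2c(/C=N\OCc3c(Cl)c(-c4ccc(F)cc4)nn3C)c(C)nn2C)cc1` gives 2050 nM in a functional assay on SMMC-7721 cells (Homo sapiens) for antiproliferative activity, read by MTT assay, with a stated time of 72 h; on this read-out lower numbers stand for stronger inhibition and higher numbers for weaker inhibition. Compound 2 `Cc1nn(C)c(Oc2ccc(OC(F)(F)F)cc2)c1/C=N\OCc1c(Cl)c(-c2ccc(F)cc2)nn1C` gives 5210 nM in this assay, and compound 3 `Cc1nn(C)c(Oc2ccc(Cl)cc2)c1/C=N\OCc1c(Cl)c(-c2ccc(Cl)cc2)nn1C` gives 6820 nM. Among these three numbers compound 2 stands second highest: it lies within the scatter of compound 3 and beyond the scatter from compound 1. Within the data shown here, the only single-place step measured so far is a 2.5-fold higher number from compound 1 to compound 2 (0.41 log units; beyond the scatter), a modest move toward weaker inhibition.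

Compound 4 `Cc1nn(C)c(Oc2ccc(OC(F)(F)F)cc2)c1/C=N\OCc1c(Cl)c(-c2ccc(Cl)cc2)nn1C` differs from compound 2 by chloro in place of fluoro on an aromatic carbon. Among the measured compounds shown here, no measured step isolates this change. Compound 3 also carries the 4-chlorophenyl, but it differs from compound 2 at a second place as well, so the two can only be set side by side, and their numbers fall within the scatter of each other. On that basis no step beyond the scatter is expected in this assay from the change. Compound 4 is estimated at 6500 nM, with a range of 3000 nM to 14000 nM. The expected step is therefore a 1.2-fold higher number from compound 2 to compound 4 (0.10 log units; within the scatter).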

Compound 4, half-maximal inhibitory concentration: 8670 nM
Compound 4: the middle estimate sits 1.3-fold (0.13 log units) below what was measured; measured number inside the range.
By their numbers in this assay, from the lowest: compound 1; then compounds 2, 3 and 4 (each within the scatter of the next).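

In this assay the change from 4-fluorophenyl to 4-chlorophenyl can now be read on its own (a 1.7-fold higher number from compound 2 to compound 4 (0.22 log units; within the scatter)), so chloro in place of fluoro at this place, para to a large group, gives no step beyond the scatter. Among these compounds, with the 4-chlorophenyl held fixed, trifluoromethoxy in place of chloro at the other aromatic ring also stays within the scatter (a 1.3-fold higher number from compound 3 to compound 4 (0.10 log units; within the scatter)), so neither new step adds to the one step beyond the scatter seen so far. No data at hand bear on the reason for either step.

Only fluoro and chloro are shown at this place, so an amine, a carboxylic acid or a longer chain there remains open. Also open, on these data alone, is whether the methoxy to trifluoromethoxy step (a 2.5-fold higher number from compound 1 to compound 2 (0.41 log units; beyond the scatter)) recurs with the 4-chlorophenyl in place.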